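Two Ring Stereocentres Inverted in Compound 2

The source may report more compounds than this note shows. Statements on the series, on what has been measured and on what is new or still open speak of the compounds shown alone.

- Compound 1 `CC(=O)N[C@@H]1CSSC(C)(C)[C@H](C(N)=O)NC(=O)[C@H](CC(=O)O)NC(=O)CNC(=O)[C@H](CCCN=C(N)N)NC1=O` gives 20300 nM; 4120 nM (2 entries)
- Compound 2 `CC(=O)N[C@@H]1CSSC(C)(C)[C@H](C(N)=O)NC(=O)[C@@H](CC(=O)O)NC(=O)CNC(=O)[C@H](CCCN=C(N)N)NC1=O` gives 4120 nM

In a functional assay (plasma) for inhibition, with Canis familiaris (Canis lupus familiaris) as the target (a higher number here means a weaker inhibitor, a lower number a stronger inhibitor), compound 2 stands at a single number (see 4120 nM), the only one available, whereas the entries for compound 1 disagree. Compound 3 `CC(=O)N[C@H]1CSSC(C)(C)[C@H](C(N)=O)NC(=O)[C@@H](CC(=O)O)NC(=O)CNC(=O)[C@@H](CCCN=C(N)N)NC1=O` keeps the same atoms and bonds as compound 2, and its change lies wholly in configuration (the two compounds have the same atoms and bonds and differ only in configuration as drawn: 2 of 4 stereo elements differ; a stereocentre at a saturated ring carbon is drawn S in compound 2 and R in compound 3; a stereocentre at a saturated ring carbon is drawn S in compound 2 and R in compound 3). Among the compounds with values here, no measured step speaks directly to this change. Within the data shown here, the one comparison of configuration rests on (the fact that compounds 1 and 2 differ only in the configuration as drawn), while the several entries of compound 1 in this assay, 20300 nM; 4120 nM (2 entries) span a range that reaches the value of compound 2, so it sets no size. A moderate loss of inhibition is expected nonetheless, with a wide margin. The expected change is a 4.9-fold higher number from compound 2 to compound 3 (0.69 log units; beyond the scatter), toward weaker inhibition. For compound 3 the estimated value is 20000 nM, with an expected range of 5000 nM to 80000 nM.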

Compound 3, half-maximal inhibitory concentration: 98700 nM
Beside the measured number, compound 3's estimate is 4.9-fold (0.69 log units) below it; measured number above the stated range.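

In this assay, a change of configuration alone, with no atom or bond altered, gives a 24-fold higher number from compound 2 to compound 3 (1.38 log units; beyond the scatter), a large loss of inhibition. The earlier comparison of configuration could put no size on such a change, as the entries for compound 1 disagree and reach the value of compound 2: the several entries of compound 1 in this assay, 20300 nM; 4120 nM (2 entries). The new pair gives the first clear size, showing that the configuration at saturated ring carbons can by itself move this read-out well beyond the scatter: the fact that compounds 2 and 3 differ only in the configuration as drawn.

Both stereocentres change together, so the compounds shown leave open whether one of them carries the step or both share it. They also leave open whether the same sensitivity to configuration would hold with a longer chain carrying the carboxylic acid, or with an amine in its place.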